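A few compounds are considered here, and "the series" means these few. Any claim that something is new, unique, unknown or untested is made for them only; others in the source may bear on it.

Compound 1 `Cc1cc2ccccc2nc1-c1cn(CCC(F)(F)C(F)(F)C(F)(F)C(F)(F)C(F)(F)C(F)(F)C(F)(F)C(F)(F)F)nn1` carries a methyl group on the shared core, and compound 2 `CCc1cc2ccccc2nc1-c1cn(CCC(F)(F)C(F)(F)C(F)(F)C(F)(F)C(F)(F)C(F)(F)C(F)(F)C(F)(F)F)nn1` carries an ethyl group in the same place. In a functional assay on HeLa cells (Homo sapiens) for cytotoxicity, read by MTT assay, with a stated time of 24 h (a lower number here means a stronger inhibitor, a higher number a weaker inhibitor), compound 1 gives > 100 ug/mL, which is a limit of the assay and not a number. In this assay compound 2 likewise gives > 100 ug/mL, again a limit rather than a measured number. Compound 2 therefore stands at the limit of > 100 ug/mL in this assay, at which 2 of the 2 values shown sit, and nothing more precise about its position is known. Compound 3 `CCCc1cc2ccccc2nc1-c1cn(CCC(F)(F)C(F)(F)C(F)(F)C(F)(F)C(F)(F)C(F)(F)C(F)(F)C(F)(F)F)nn1` extends the chain once more: methyl in place of hydrogen on a saturated chain carbon, two bonds along the chain from an aromatic carbon. Among the measured compounds shown here, the only measured step that bears on this change is a step that the two limits leave unreadable from compound 1 to compound 2, the same kind of lengthening one bond closer to the core, and its size cannot be read because both of its ends sit at the limit of > 100 ug/mL in this assay, at which 2 of the 2 values shown sit. So no direction or size is expected beyond the scatter. Compound 3 is expected to remain at the limit, with an estimated step that the limit leaves unreadable from compound 2 to compound 3 and an estimated value of 150 ug/mL, ranging from 50 ug/mL to 500 ug/mL.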

Compound 3, half-maximal inhibitory concentration: 37.8 ug/mL
Compound 3: the middle estimate sits 4.0-fold (0.60 log units) above what was measured; measured number below the stated range.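

At this position on the shared core, the length of the chain can change the result in this assay: methyl in place of hydrogen on a saturated chain carbon, two bonds along the chain from an aromatic carbon, gives an at least 2.6-fold lower number from compound 2 to compound 3 (0.42 log units; beyond the scatter). The whole change in chain length gives an at least 2.6-fold lower number from compound 1 to compound 3 (0.42 log units; beyond the scatter). Both steps give only a minimum size, because the values they start from are limits of the assay, not numbers: the limit of > 100 ug/mL in this assay, at which 2 of the 3 values shown sit.

On these data alone, whether a butyl group or a longer chain at this position would lower the number further or raise it again stays open. Also open, as far as these compounds go, is whether an amine or a carboxylic acid at the end of the propyl chain would keep the value that compound 3 gives, 37.8 ug/mL, in this assay.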